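Sulfamoylurea series: alkoxy variation on the sulfonyl sulfur

A few compounds are considered here, and "the series" means these few. Any claim that something is new, unique, unknown or untested is made for them only; others in the source may bear on it.

Measured compounds:
compound 1 `CC(C)c1cccc(C(C)C)c1NC(=O)NS(=O)(=O)N(C(C)C)C(C)(C)C` — 140 nM
compound 2 `CCCCCCOS(=O)(=O)NC(=O)Nc1c(C(C)C)cccc1C(C)C` — 27000 nM
compound 3 `CCCCCCC(C)OS(=O)(=O)NC(=O)Nc1c(C(C)C)cccc1C(C)C` — 35000 nM

All three share the same urea-linked core; they differ only in the group on the sulfonyl sulfur. In an assay on liver for inhibition of sterol O-acyltransferase 1 (Rattus norvegicus), using microsomes (on this read-out higher numbers stand for weaker inhibition and lower numbers for stronger inhibition), compound 1 carries the isopropyl(tert-butyl)amino group and gives 140 nM. Replacing it with an alkoxy group costs a great deal: a 190-fold higher number from compound 1 to compound 2 (2.29 log units; beyond the scatter) and a 250-fold higher number from compound 1 to compound 3 (2.40 log units; beyond the scatter). Among the compounds shown, compound 3 has the highest number, though its gap to compound 2 is within the scatter, as a 1.3-fold higher number from compound 2 to compound 3 (0.11 log units; within the scatter) shows.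

Compound 4 `CCCCCCCCCCOS(=O)(=O)NC(=O)Nc1c(C(C)C)cccc1C(C)C` is the next member, differing from compound 3 only in the chain on the oxygen: decyl in place of 1-methylheptyl on an oxygen. Among the compounds with values here, the only measured step that bears on this change is the chain swap on the oxygen between compound 2 and compound 3, which stayed within the scatter. A chain change of similar kind is therefore expected to give no step beyond the scatter in this assay; the expected step is no change at the digits printed from compound 3 to compound 4 (within the scatter). Compound 4 is estimated at 35000 nM, with a range from 14000 nM to 90000 nM.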

Compound 4, half-maximal inhibitory concentration: > 10000 nM
Compound 4 gave a limit, no number; the forecaster's own chance of this, stated with the estimate: 15%; the middle value does not contradict the limit.
By their numbers in this assay, from the lowest: compound 1; then compounds 2 and 3 (each within the scatter of the next).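

In this assay compound 4 gives > 10000 nM, which is a limit and not a number. Within the data shown here, no step from compound 2 or compound 3 to compound 4 can be read. As far as these compounds go, whether decyl on the oxygen differs from hexyl or 1-methylheptyl in this read-out remains open.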